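The compounds below may be only part of what the source reports. "The series", "measured", "known", "first", "only" and "open" are said of these compounds alone.

Measured in a functional assay on HepG2 cells (Homo sapiens) for antiproliferative activity, read by MTT assay, with a stated time of 72 h; on this read-out higher numbers stand for weaker inhibition and lower numbers for stronger inhibition:

- compound 1 `COc1ccc(N2C(=O)COc3ccc(-c4cnc(Cl)c(NS(=O)(=O)c5ccc(F)cc5)c4)cc32)cc1` gives > 40000 nM, a limit of the assay
- compound 2 `Cc1ccc(N2C(=O)COc3ccc(-c4cnc(Cl)c(NS(=O)(=O)c5ccc(F)cc5)c4)cc32)cc1` gives 39600 nM
- compound 3 `O=C1COc2ccc(-c3cnc(Cl)c(NS(=O)(=O)c4ccc(F)cc4)c3)cc2N1c1ccc(Cl)cc1` gives 33900 nM

Compound 1 has no number on this read-out, only a limit, and it stands at the limit of > 40000 nM in this assay, at which 1 of the 3 values shown sits.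

Compound 4 `COc1ccc(N2C(=O)COc3ccc(-c4cnc(OC)c(NS(=O)(=O)c5ccc(F)cc5)c4)cc32)cc1` keeps the rest of compound 1 and differs from it by methoxy in place of chloro on an aromatic carbon. This is methoxy in place of chloro on an aromatic carbon of a six-membered aromatic ring with 1 nitrogen, next to the ring nitrogen and ortho to a ((4-fluorophenyl)sulfonyl)amino group.

Going by the values given here, no measured step covers this place. The three that exist all change a different aromatic carbon, and they give only indirect guidance: a number no higher from compound 1 to compound 2 (the limit leaves the size open), then an at least 1.1-fold lower number from compound 1 to compound 3 (0.07 log units; that floor lies within the scatter), and a 1.2-fold lower number from compound 2 to compound 3 (0.07 log units; within the scatter). None of them is shown beyond the scatter, and all three compounds sit in the same weak region of the read-out.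

Resting on the one fully sized step, a 1.2-fold lower number from compound 2 to compound 3 (0.07 log units; within the scatter), no change beyond the scatter and no firm direction is expected in this assay for the new swap. The expected step is an at least 1.3-fold lower number from compound 1 to compound 4 (0.12 log units; that floor lies within the scatter) and remains an estimate. For compound 4 the estimated value is 30000 nM, with an expected range from 12000 nM to 60000 nM, and the assay may again report only a limit.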

Compound 4, half-maximal inhibitory concentration: 13100 nM
Compound 4: the middle estimate sits 2.3-fold (0.36 log units) above what was measured; measured number inside the range.
By their numbers in this assay, from the lowest: compound 4; then compounds 3 and 2 (each within the scatter of the next). At a limit, above all of these: compound 1.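

In this assay, methoxy in place of chloro on the aromatic carbon next to the ring nitrogen and ortho to a ((4-fluorophenyl)sulfonyl)amino group gives an at least 3.0-fold lower number from compound 1 to compound 4 (0.48 log units; beyond the scatter). This is the only step among the compounds shown that is printed as beyond the scatter, so this position can move the read-out, whereas the swaps on the other aromatic carbon were not shown to do so. The true size of the step stays open because compound 1 has only a limit and no number: the limit of > 40000 nM in this assay, at which 1 of the 4 values shown sits.

On these data alone, only chloro and methoxy appear at this position, so it remains open whether an amine, a hydroxyl group or a longer alkoxy chain there would lower the number further or lose the change. As far as these compounds go, it is also open whether the same swap would give a step of similar size with the methyl of compound 2 or the chloro of compound 3 in place of the methoxy that compound 4 keeps from compound 1.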